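From 4-methoxyphenyl to benzyloxy on a carbonyl carbon

A few compounds are considered here, and "the series" means these few. Any claim that something is new, unique, unknown or untested is made for them only; others in the source may bear on it.

Measured in an ADME assay on Vero cells (Chlorocebus sabaeus) for cytotoxicity, read by resazurin assay, with a stated time of 3 days; a higher number here means a weaker inhibitor, a lower number a stronger inhibitor:
Compound 1 `CCN(CC)c1cc2[nH]c(C3CCCCC3)nc2cc1NC(=O)c1ccc(N(C)C)cc1`: "not determined" (no result reported)
Compound 2 `COc1ccc(C(=O)Nc2cc3nc(C4CCCCC4)[nH]c3cc2N(C)C)cc1`: > 100 ug/mL, a limit of the assay
Compound 3 `COc1ccc(C(=O)Nc2cc3nc(C4CCCCC4)[nH]c3cc2N2CCCC2)cc1`: > 100 ug/mL, a limit of the assay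

Compound 2 stands at a limit, > 100 ug/mL, and has no exact number. The series offers no exact number at all, for its readings stop at the limit of > 100 ug/mL in this assay, at which 2 of the 3 values shown sit. For the measured compounds named here, the only measured step is a step that the two limits leave unreadable from compound 2 to compound 3, with pyrrolidin-1-yl in place of dimethylamino on an aromatic carbon. That step concerns a different group from the one changing here, and it gives no size to carry over.

Compound 4 `CN(C)c1cc2[nH]c(C3CCCCC3)nc2cc1NC(=O)OCc1ccccc1` is the next to be read, and its change from compound 2 is benzyloxy in place of 4-methoxyphenyl on a carbonyl carbon. The two have the same atoms, joined differently.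

The limit of compound 2, > 100 ug/mL, is therefore the only anchor for an expectation in this assay. The expected step is a number no higher from compound 2 to compound 4 (the limit leaves the size open), with no move in either direction expected beyond the scatter. For compound 4 the estimate is 100 ug/mL, with an expected range from 40 ug/mL to 200 ug/mL.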

Compound 4, half-maximal inhibitory concentration: > 100 ug/mL
Compound 4 gave a limit, no number; the forecaster's own chance of this, stated with the estimate: 75%; the middle value sits exactly at the limit.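

Compound 2 and compound 4 each stand at a limit, not a number, in this assay, so no new step between them can be read: the limit of > 100 ug/mL in this assay, at which 3 of the 4 values shown sit.

The compounds shown leave open how far past that limit each reading lies, and whether benzyloxy in place of 4-methoxyphenyl on a carbonyl carbon changes it at all.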